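Switching the benzyl group for a pentyl chain

The source may report more compounds than this note shows. Statements on the series, on what has been measured and on what is new or still open speak of the compounds shown alone.

Measured so far:
Compound 1, `CCc1nncn1-c1ccc(OCc2ccccc2)cc1`: 20.8 mg/kg
Compound 2, `CCc1nncn1-c1ccc(OCc2ccccc2F)cc1`: 21.2 mg/kg
Compound 3, `CCc1nncn1-c1ccc(OCc2ccc(Cl)cc2)cc1`: 19.7 mg/kg

All three compounds were tested in a functional assay on the whole organism (strain C57B/6) with Mus musculus as the target, in the maximal electroshock model; on this read-out higher numbers stand for an effect only at larger amounts of compound and lower numbers for an effect already at smaller amounts. Compound 3 has the lowest number of the three, but its steps to the others are small: a 1.1-fold lower number from compound 1 to compound 3 (0.02 log units; within the scatter) and a 1.1-fold lower number from compound 2 to compound 3 (0.03 log units; within the scatter), both within the scatter, so nothing separates it from compound 1 or compound 2.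

Compound 4, `CCCCCCOc1ccc(-n2cnnc2CC)cc1`, has not yet been measured in this assay. Relative to compound 3 the change is pentyl in place of 4-chlorophenyl on a saturated chain carbon bound to an oxygen on an aromatic ring. The measured steps all concern substituents on the aromatic ring that is now removed: a 1.0-fold higher number from compound 1 to compound 2 (0.01 log units; within the scatter), a 1.1-fold lower number from compound 1 to compound 3 (0.02 log units; within the scatter) and a 1.1-fold lower number from compound 2 to compound 3 (0.03 log units; within the scatter), none beyond the scatter. Within the data shown here, no measured step exchanges the ring itself for a chain, so there is no direct precedent for this change. The expectation therefore rests on the observation that modest changes at this part of the molecule have left the numbers flat, while the wider range allows for the larger, untested change. Compound 4 is expected to give 24 mg/kg in this assay, with a range from 12 mg/kg to 50 mg/kg. This estimate corresponds to a 1.2-fold higher number from compound 3 to compound 4 (0.09 log units; within the scatter), a step expected to stay close to the scatter.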

Compound 4, dose for half-maximal effect: 13.2 mg/kg
The estimate for compound 4 lay 1.8-fold (0.26 log units) above the measured number, within the range that was stated.
By their numbers in this assay, from the lowest: compounds 4, 3, 1 and 2 (each within the scatter of the next).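

In this assay, among these compounds, the earlier compounds varied only the substituents on the aromatic ring, whereas here the whole ring goes and a pentyl chain takes its place on a saturated chain carbon bound to an oxygen on an aromatic ring. That exchange gives a 1.5-fold lower number from compound 3 to compound 4 (0.17 log units; within the scatter) and a 1.6-fold lower number from compound 2 to compound 4 (0.21 log units; within the scatter) and also a 1.6-fold lower number from compound 1 to compound 4 (0.20 log units; within the scatter), so all three steps stay within the usual scatter and show that, in this series, a ring at this position is not required for an effect at doses similar to those of the benzyl compounds. Nothing available explains why the ring and the chain can stand in for each other here.

The compounds shown leave open how far this tolerance extends, since a single chain cannot show whether length matters, and a shorter chain such as propyl or a longer one such as decyl could behave differently. They also leave open whether a chain ending in an amine or a carboxylic acid would be accepted at this position, as every group shown here carries no net charge.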